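The source may hold more compounds than are shown below. What is called first, only, known or untested is meant among the compounds shown, and "the series" means these compounds.

Measured compounds:
compound 1 `COc1ncnc2c1c(I)cn2[C@@H]1O[C@H](CO)[C@@H](O)[C@H]1O` gives 91000 nM in an ADME assay on BJ cells (Homo sapiens), read by MTT assay, with a stated time of 72 h; a higher number here means a weaker inhibitor, a lower number a stronger inhibitor
compound 2 `COc1ncnc2c1c(-c1cccs1)cn2[C@@H]1O[C@H](CO)[C@@H](O)[C@H]1O` gives 62800 nM
compound 3 `COc1ncnc2c1c(-c1ccccc1)cn2[C@@H]1O[C@H](CO)[C@@H](O)[C@H]1O` gives > 100000 nM, a limit of this assay, not a number

Compound 2 stands lowest of the two numbers shown; its nearest neighbour is compound 1, a step of a 1.4-fold lower number from compound 1 to compound 2 (0.16 log units; within the scatter), which lies within the scatter. Compound 3 sits at the limit of > 100000 nM in this assay, at which 1 of the 3 values shown sits. Of the steps measured, from compound 2 to compound 3 gave an at least 1.5-fold higher number from compound 2 to compound 3 (0.20 log units; that floor lies within the scatter), and from compound 1 to compound 3 gave an at least 1.0-fold higher number from compound 1 to compound 3 (0.04 log units; that floor lies within the scatter), both floors within the scatter.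

Compound 4 `CNc1ncnc2c1c(-c1cccs1)cn2[C@@H]1O[C@H](CO)[C@@H](O)[C@H]1O` differs from compound 2 by methylamino in place of methoxy on an aromatic carbon. For the measured compounds named here, none of the measured steps touches this part of the shared core; all three concern the group on the five-membered ring and all lie within the scatter. There is therefore no measured basis for expecting a step beyond the scatter, in either direction, in this assay. The account expects compound 4 to give about 60000 nM, between 20000 nM and 150000 nM, an expected step of a 1.0-fold lower number from compound 2 to compound 4 (0.02 log units; within the scatter) that stays within the usual scatter.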

Compound 4, half-maximal inhibitory concentration: > 100000 nM
Compound 4 was reported as a limit (the forecaster's own chance of this, stated with the estimate: 30%); at least 1.6-fold (0.22 log units) between middle value and limit.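

For the compounds shown here, the change of methoxy to methylamino on an aromatic carbon of the six-membered aromatic ring is the first measured change at this position, since the earlier steps all concerned the group on the five-membered ring. It gave an at least 1.5-fold higher number from compound 2 to compound 4 (0.20 log units; that floor lies within the scatter), so this step has only a floor, and that floor does not set compound 4 apart from compound 2 in this assay. Compound 4 is reported only as a limit, as is compound 3: the limit of > 100000 nM in this assay, at which 2 of the 4 values shown sit.

The compounds shown leave open how large this step really is, since a limit gives no number to set against compound 2. They also leave open how a plain amino group or an ethoxy group would read at this position, and whether methylamino would behave alike with iodo or phenyl in place of thiophen-2-yl.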